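Removing the Sulfonamide from a Weak Biphenyl Inhibitor

A few compounds are considered here, and "the series" means these few. Any claim that something is new, unique, unknown or untested is made for them only; others in the source may bear on it.

Of the compounds shown here, three have been measured in an assay on COS-7 cells for inhibition of patatin-like phospholipase domain-containing protein 2 (Mus musculus); a higher number here means a weaker inhibitor, a lower number a stronger inhibitor. Compound 1 `CCOC(=O)c1cc(-c2ccc(OCC)cc2)ccn1` gives 105000 nM, compound 2 `CCOC(=O)c1ccc(-c2ccc(OCC)cc2)s1` gives 70000 nM, and compound 3 `CCNS(=O)(=O)c1cccc(-c2ccc(OCC)cc2)c1` gives 200000 nM. Compound 3 and compound 1 lie within the usual scatter of each other, so no order between them can be read from these numbers, while compound 2 gives a lower number than compound 3 by a margin beyond the scatter.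

Compound 4 `CCOc1ccc(-c2ccccc2)cc1` has not yet been measured. It differs from compound 3 in one place: hydrogen in place of ethylsulfamoyl on an aromatic carbon. With that change the whole sulfonamide portion of compound 3 is gone, and what remains is only the two aromatic rings and the ethoxy chain.

Within the data shown here, no measured pair shows what such a removal does in this assay. Since compound 3 already gives 200000 nM, compound 4 is expected to give a similar or higher number, with a step of about a 1.5-fold higher number from compound 3 to compound 4 (0.18 log units; within the scatter). The estimate for compound 4 is 300000 nM, within a range of 100000 nM to 1000000 nM, and a result reported only as a limit would not be surprising.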

Compound 4, half-maximal inhibitory concentration: > 200000 nM
Compound 4 ended at the assay's limit; the forecaster's own chance of this, stated with the estimate: 40%; the middle value does not contradict the limit.
By their numbers in this assay, from the lowest: compounds 2, 1 and 3 (each within the scatter of the next, the first and the last beyond it).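

Compound 4 gives > 200000 nM in this assay, which is a limit of the assay and not a number. Replacing ethylsulfamoyl with hydrogen on this aromatic carbon gives a number no lower from compound 3 to compound 4 (the limit leaves the size open), so this first single-place change shows that removing the whole group brings no lower number, and that the two aromatic rings with the ethoxy chain alone do not yield a readable value in this series. How much ethylsulfamoyl contributes cannot be read, since the result rests on the limit: the limit of > 200000 nM in this assay, at which 1 of the 4 values shown sits.

On these data alone, whether an amine or a carboxylic acid on this aromatic carbon would give a lower number than hydrogen remains open. Also open, as far as these compounds go, is whether a longer chain in place of the ethyl on the sulfonamide would shift the number at all.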